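Compound 1 to compound 4: hydroxy in place of chloro

The source may hold more compounds than are shown below. What is called first, only, known or untested is meant among the compounds shown, and "the series" means these compounds.

Compound 1 (`O=C(Cl)c1ccc2occc(=O)c2c1`) "nd(insoluble)" (no result reported)
Compound 2 (`O=C(O)CCCCCNC(=O)c1cc(=O)c2ccccc2o1`) > 18 ug/mL
Compound 3 (`O=C(O)CCCNC(=O)c1cc(=O)c2ccccc2o1`) > 18 ug/mL

In a functional assay on cells (Mast cell, Rattus norvegicus) for inhibition, with a stated time of 15 min (on this read-out higher numbers stand for an effect only at larger amounts of compound and lower numbers for an effect already at smaller amounts), compound 1 gives "nd(insoluble)" (no result reported) and so has no number to start from. Compound 2 stands at > 18 ug/mL and this is a limit of the assay. Compound 3 stands at > 18 ug/mL and this too is a limit.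

Compound 4 (`O=C(O)c1ccc2occc(=O)c2c1`) differs from compound 1 by a single exchange (hydroxy in place of chloro on a carbonyl carbon), hydroxy in place of chloro on a carbonyl carbon. Among the measured compounds shown here, no measured step covers this exchange. For the measured compounds named here, the one step available (a step that the two limits leave unreadable from compound 2 to compound 3) has no readable size and lies on a saturated chain carbon, so it offers no guide to size or direction. With no number for compound 1, no step can be expected from it in either direction.

The expectation therefore rests on compound 3 with its limit of > 18 ug/mL and on the limit of > 18 ug/mL in this assay, at which 2 of the 3 values shown sit, as the only reference point. A report of a limit again seems the likeliest outcome. In this assay compound 4 is estimated at about 20 ug/mL with an expected range from 6 ug/mL to 60 ug/mL as its loose bounds.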

Compound 4, concentration for half-maximal effect: > 18 ug/mL
Compound 4: only a limit was reported; the forecaster's own chance of this, stated with the estimate: 75%; the middle value does not contradict the limit.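

In this assay compound 4 gives > 18 ug/mL, which is a limit of the assay. Among the compounds shown here, compound 1 has no reported number, so no step from compound 1 to compound 4 can be read. The compounds shown leave open how far hydroxy in place of chloro shifts the concentration for half-maximal effect in this assay.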